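The source may report more compounds than this note shows. Statements on the series, on what has been measured and on what is new or still open speak of the compounds shown alone.

Compound 1 `CC(C(=O)NCc1ccc(C(F)(F)F)cc1N1CCC(C)(C)CC1)c1ccc(NS(C)(=O)=O)c(F)c1` belongs to a group of three analogues that share a common core and differ only in the group on one aromatic carbon. In an assay on CHO cells for antagonist activity at transient receptor potential cation channel subfamily V member 1 (Homo sapiens), read by FLIPR (a higher number here means a weaker inhibitor, a lower number a stronger inhibitor), compound 1 gives 1.3 nM, which is the second highest of the three numbers. Compound 2 `CC(C(=O)NCc1ccc(C(F)(F)F)cc1N1CCN(C2CCCCC2)CC1)c1ccc(NS(C)(=O)=O)c(F)c1` gives 13.8 nM in this assay, and compound 3 `CC(C(=O)NCc1ccc(C(F)(F)F)cc1SC1CCCC1)c1ccc(NS(C)(=O)=O)c(F)c1` gives 0.3 nM. The step of an 11-fold higher number from compound 1 to compound 2 (1.03 log units; beyond the scatter) is large, the step of a 4.3-fold lower number from compound 1 to compound 3 (0.64 log units; beyond the scatter) is modest, and the step of a 46-fold lower number from compound 2 to compound 3 (1.66 log units; beyond the scatter) spans both of them.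

Compound 4 `CC(C(=O)NCc1ccc(C(F)(F)F)cc1C1CCCCC1)c1ccc(NS(C)(=O)=O)c(F)c1` has not yet been measured in this assay. It differs from compound 1 in a single place: cyclohexyl in place of 4,4-dimethylpiperidin-1-yl on an aromatic carbon. Both measured steps from compound 1 bear on this change, since each also exchanges the group on that aromatic carbon. A group with a saturated ring and no hydrogen-bond acceptor, cyclopentylsulfanyl, gave the lower number in compound 3, while the larger 4-cyclohexylpiperazin-1-yl gave the higher number in compound 2. Cyclohexyl resembles the former more than the latter, so a small downward step or none beyond the scatter is expected. Compound 4 is therefore estimated at 0.8 nM, with a range from 0.25 nM to 2.5 nM. This estimate amounts to an expected step of a 1.6-fold lower number from compound 1 to compound 4 (0.21 log units; within the scatter).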

Compound 4, inhibition constant: 0.6 nM
Estimate against measurement, compound 4: 1.3-fold (0.12 log units) above; low and high end bracket the measured number.
By their numbers in this assay, from the lowest: compounds 3 and 4 (each within the scatter of the next); then compound 1; then compound 2.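

In this assay, the step of a 2.2-fold lower number from compound 1 to compound 4 (0.34 log units; beyond the scatter) shows that this aromatic carbon, ortho to a large group and meta to a trifluoromethyl group, accepts a six-membered non-aromatic ring of carbon only, and that the ring nitrogen of 4,4-dimethylpiperidin-1-yl is not needed for a low number. The step of a 2.0-fold higher number from compound 3 to compound 4 (0.30 log units; within the scatter) puts cyclohexyl level with cyclopentylsulfanyl, so the sulfur of compound 3 is not required either for a number in this range. The step of a 23-fold lower number from compound 2 to compound 4 (1.36 log units; beyond the scatter) adds a sharper point: compound 2 and compound 4 both carry a cyclohexyl ring, so that ring alone does not bring the high number, which comes only with 4-cyclohexylpiperazin-1-yl in this set.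

Nothing among the data shown explains why these groups differ as they do. On these data alone, it remains open how the numbers would respond to a phenyl ring, a directly attached cyclopentyl or a morpholin-4-yl on this carbon, and whether a piperazine without the cyclohexyl would behave like compound 2.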